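Same Chlorine Change Tried on a Second Core

A few compounds are considered here, and "the series" means these few. Any claim that something is new, unique, unknown or untested is made for them only; others in the source may bear on it.

Compound 1, `CCOC(=O)Cc1nc(N)n(C(=O)c2ccccc2)n1`, gives 31.6% in a functional assay on the whole organism (strain albino) for inhibition, with Rattus norvegicus as the target, read by paw edema, with stated times of 30 min and 1 h, at a dose of 5 mg/kg by the oral route; a lower number here means less inhibition, a higher number more inhibition at the dose given (going by the name of the read-out).
Compound 2, `CCOC(=O)Cc1nc(N)n(C(=O)c2ccc(Cl)cc2)n1`, gives 34.2% in this assay.
Compound 3, `CCOC(=O)Cc1n[nH]c(NC(=O)c2ccccc2)n1`, gives 26.8% in this assay.

Compounds 1 and 2 differ by one change, (chloro in place of hydrogen on an aromatic carbon), and the step it made was a number 2.6 percentage points higher from compound 1 to compound 2 (within the scatter). Compound 3 has the same atoms as compound 1 joined differently; the difference between the two cores is not broken down here. Compound 4, `CCOC(=O)Cc1n[nH]c(NC(=O)c2ccc(Cl)cc2)n1`, has not been measured; it carries the same change on the core of compound 3, namely (chloro in place of hydrogen on an aromatic carbon), at a place described in the same words as before.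

The step from compound 3 to compound 4 in this assay is expected to be a number 2.2 percentage points higher from compound 3 to compound 4 (within the scatter), because the same change gave a number 2.6 percentage points higher from compound 1 to compound 2 (within the scatter). Compound 4 is therefore estimated to give 29%, expected to fall between 18% and 40%.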

Compound 4, a percentage reported as inhibition, in the whole organism at one dose (the size of the read-out at that dose, not a potency): 31.1%
Estimate against measurement, compound 4: 2.1 percentage points below; measured number inside the range.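

In this assay, the change from phenyl to 4-chlorophenyl on the second core gave a number 4.3 percentage points higher from compound 3 to compound 4 (within the scatter). Set beside the step on the first core, the change carried over with no difference that can be told apart: the same change on two cores in this assay, a number 2.6 percentage points higher (within the scatter) from compound 1 to compound 2 and a number 4.3 percentage points higher (within the scatter) from compound 3 to compound 4, 1.7 percentage points apart, within the scatter of two such steps
Among these compounds, this shows only that the two steps agree; each lies within the scatter on its own, so it does not show that the chloro group alters inhibition on either core, and two cores cannot speak for the whole series.

On these data alone, how a methoxy group or an amine would behave in place of the chloro group stays open. So does whether either would give the same step on both cores.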